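The source may report more compounds than this note shows. Statements on the series, on what has been measured and on what is new or still open speak of the compounds shown alone.

Compound 2 `COc1ccc(CNC(=O)/C(C#N)=C/c2ccc(C)o2)cc1` stands lowest of the two numbers seen in a functional assay on BE(2)-C cells (Homo sapiens) for inhibition, read by MTT assay, with a stated time of 72 h (a lower number here means a stronger inhibitor of growth, a higher number a weaker inhibitor of growth), where compound 2 gives 21000 nM. Its nearest neighbour is compound 1 `N#C/C(=C\c1ccc([N+](=O)[O-])cc1)C(=O)c1c[nH]c2ccccc12`, which in this assay gives 40000 nM, a gap within the usual scatter. Compound 3 `COc1ccc(CNC(=O)/C(C#N)=C/c2ccc(-c3ccccc3)o2)cc1` reaches only a limit of this assay, > 100000 nM, and sits at the limit of > 100000 nM in this assay, at which 1 of the 3 values shown sits. Within the data shown here, the one measured step, an at least 4.7-fold higher number from compound 2 to compound 3 (0.67 log units; beyond the scatter), swaps phenyl for methyl on an aromatic carbon, a different change from the one at hand. Compound 4 `COc1ccc(CNC(=O)/C(C#N)=C/c2ccc(C)cc2)cc1` differs from compound 2 by 4-methylphenyl in place of 5-methylfuran-2-yl on a double-bonded chain carbon bound to a double-bonded chain carbon. Among the measured compounds shown here, no measured step mirrors this swap, so compound 4 is expected to stay near compound 2, its estimated step being a 1.4-fold higher number from compound 2 to compound 4 (0.15 log units; within the scatter). Compound 4 is therefore estimated at 30000 nM, within 10000 nM to 90000 nM.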

Compound 4, concentration for 50% growth inhibition: 35000 nM
Estimate against measurement, compound 4: 1.2-fold (0.07 log units) below; low and high end bracket the measured number.
By their numbers in this assay, from the lowest: compounds 2, 4 and 1 (each within the scatter of the next). At a limit, above all of these: compound 3.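

Replacing 5-methylfuran-2-yl with 4-methylphenyl gives a 1.7-fold higher number from compound 2 to compound 4 (0.22 log units; within the scatter), so in this assay the two compounds cannot be told apart. Where the earlier step changed only the group carried on the furan ring, this one replaces the ring itself, and the ring oxygen can go without a shift beyond the scatter. The data shown give no cause for this result.

Going by these compounds, it remains open whether a pyridine ring at this place would read the same in this assay. The same question holds for a phenyl ring carrying a carboxylic acid or an amine instead of the methyl.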